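Chain terminus variation on the shared core: compound 4

A few compounds are considered here, and "the series" means these few. Any claim that something is new, unique, unknown or untested is made for them only; others in the source may bear on it.

Compound 3 `CCOc1ccc2c(Cl)ccnc2c1` gives 3460 nM in a functional assay on SK-OV-3 cells (Homo sapiens) for cytotoxicity, read by MTT assay, with a stated time of 48 h (on this read-out higher numbers stand for weaker inhibition and lower numbers for stronger inhibition), and stands lowest of the two numbers shown, with compound 1 `CCCCCCCCOc1ccc2c(Cl)ccnc2c1` nearest at 4300 nM. Compound 2 `CCCCCCOc1ccc2c(Cl)ccnc2c1` gives only a limit of the assay, > 10000 nM, as noted in the limit of > 10000 nM in this assay, at which 1 of the 3 values shown sits. Compound 4 `Clc1ccnc2cc(OCCCc3ccccc3)ccc12` arises from compound 3 by benzyl in place of hydrogen on a saturated chain carbon, two bonds along the chain from an oxygen on an aromatic ring. The measured steps at this place bear on it: a 1.2-fold lower number from compound 1 to compound 3 (0.09 log units; within the scatter) and an at least 2.8-fold lower number from compound 2 to compound 3 (0.46 log units; beyond the scatter). Building out the chain at this place thus gave either no step beyond the scatter or a higher number, so for compound 4 a step of a 1.4-fold higher number from compound 3 to compound 4 (0.16 log units; within the scatter) is expected, flat to somewhat higher. The estimate for compound 4 is 5000 nM, between 2500 nM and 12000 nM.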

Compound 4, half-maximal inhibitory concentration: 3610 nM
Compound 4: the middle estimate sits 1.4-fold (0.14 log units) above what was measured, within the range that was stated.
By their numbers in this assay, from the lowest: compounds 3, 4 and 1 (each within the scatter of the next). At a limit, above all of these: compound 2.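

In this assay, benzyl in place of hydrogen at this place leaves the number flat, with a 1.0-fold higher number from compound 3 to compound 4 (0.02 log units; within the scatter), and phenyl in place of pentyl does the same, with a 1.2-fold lower number from compound 1 to compound 4 (0.08 log units; within the scatter). Phenyl in place of propyl gives an at least 2.7-fold lower number from compound 2 to compound 4 (0.44 log units; beyond the scatter), the only new step beyond the scatter, and one end of it is a limit: the limit of > 10000 nM in this assay, at which 1 of the 4 values shown sits.

A six-membered aromatic ring at the chain end thus fits the flat set of compound 1, compound 3 and compound 4, with compound 2 against it. As far as these compounds go, whether an amine or a carboxylic acid at the chain end would stay in this set remains open.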